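A 4-hydroxyphenyl group replaces thiophen-2-yl in compound 1

The compounds below may be only part of what the source reports. "The series", "measured", "known", "first", "only" and "open" are said of these compounds alone.

In a functional assay on LOX IMVI cells (Homo sapiens) for cytotoxicity (a higher number here means a weaker inhibitor of growth, a lower number a stronger inhibitor of growth), compound 1 `OCCCCC#Cc1ccccc1C#Cc1cccs1` gives 13900 nM. Compound 3 `OCCCCC#Cc1ccccc1C#Cc1cccc(C(F)(F)F)c1` gives 17500 nM, and the two values lie within the scatter of each other, so this pair cannot be told apart. Compound 2 `CSc1ccccc1C#Cc1ccccc1C#CCCCCO` gives 5800 nM, a number lower than that of compound 1 by more than the scatter. Compound 1 therefore stands level with compound 3 and above compound 2 on these three numbers.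

Compound 4 `OCCCCC#Cc1ccccc1C#Cc1ccc(O)cc1` has not yet been measured. It departs from compound 1 in one place, with 4-hydroxyphenyl in place of thiophen-2-yl on a triple-bonded carbon. Going by the values given here, no pair of measured compounds differs by a single change that could serve as a direct guide, so any forecast rests on the spread of the values alone. That spread is modest, running from compound 2 at 5800 nM to compound 3 at 17500 nM. A small effect is expected in this assay. The expected step is a 1.4-fold lower number from compound 1 to compound 4 (0.14 log units; within the scatter), a slight move towards a lower number that is estimated to stay within the scatter. For compound 4 the estimate is 10000 nM, with an expected range from 4500 nM to 22000 nM.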

Compound 4, concentration for 50% growth inhibition: 13600 nM
For compound 4 the middle estimate is 1.4-fold (0.13 log units) below the measured one; the measured number falls inside the stated range.
By their numbers in this assay, from the lowest: compound 2; then compounds 4, 1 and 3 (each within the scatter of the next).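

In this assay, going by these compounds alone, putting 4-hydroxyphenyl in place of thiophen-2-yl on a triple-bonded carbon gives a 1.0-fold lower number from compound 1 to compound 4 (0.01 log units; within the scatter), the first step in this set that isolates a single change, and it leaves the two compounds indistinguishable. At this position, a five-membered aromatic ring with 1 hetero atom and 0 hydrogen-bond donors can thus give way to a six-membered aromatic ring of carbon only with 1 hydrogen-bond donor, with no difference that this assay can resolve. No measurement is available to explain this result.

Within the data shown here, whether this holds beyond the one pair remains open: a plain phenyl, or an amine or a carboxylic acid in place of the hydroxy group of 4-hydroxyphenyl, might or might not leave the number within the scatter of that of compound 1. This single step also speaks only to this one position, and it says nothing about changes elsewhere on the shared core, such as a longer chain in place of the one ending in the alcohol.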